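The compounds below may be only part of what the source reports. "The series", "measured", "known", "first", "only" and "open" are said of these compounds alone.

Measured so far in an ADME assay on L6 cells (Rattus norvegicus) for cytotoxicity; a higher number here means a weaker inhibitor, a lower number a stronger inhibitor:
compound 1 `CCN1CCN(CCN2CCC3(N4CCCC4)CC(c4ccccc4)C2C(c2ccccc2)C3)CC1`: 53600 nM
compound 2 `c1ccc(C2CC3(N4CCCCC4)CC(NCN4CCCC4)C2C(c2ccccc2)C3)cc1`: 43000 nM
compound 3 `CCN1CCN(CCN2CCC3(N4CCCCC4)CC(c4ccccc4)C2C(c2ccccc2)C3)CC1`: 67500 nM

Compound 1 holds the second highest of the three numbers; its gaps to compound 2 and to compound 3 both lie within the scatter, so the three compounds cannot be ordered on this assay.

Compound 4 `CN1CCN(CCC(=O)N2CCC3(N4CCCC4)CC(c4ccccc4)C2C(c2ccccc2)C3)CC1` is not yet measured. It differs from compound 1 in one place: (2-(4-methylpiperazin-1-yl)ethyl)carbonyl in place of 2-(4-ethylpiperazin-1-yl)ethyl on an amine nitrogen in a ring.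

For the measured compounds named here, the only step measured in one place, a 1.3-fold higher number from compound 1 to compound 3 (0.10 log units; within the scatter), concerns a different ring and stays within the scatter; no measured step touches the amine nitrogen in the ring. With all three numbers close together, no movement beyond the scatter is expected for compound 4 in this assay, and the estimated step of a 1.1-fold lower number from compound 1 to compound 4 (0.03 log units; within the scatter) is accordingly small, with a wide range around it. The expected value for compound 4 is 50000 nM, between 15000 nM and 160000 nM.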

Compound 4, half-maximal inhibitory concentration: 75400 nM
Beside the measured number, compound 4's estimate is 1.5-fold (0.18 log units) below it, within the range that was stated.
By their numbers in this assay, from the lowest: compounds 2, 1, 3 and 4 (each within the scatter of the next).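

In this assay, the amine nitrogen in the ring now has its first measured step, and a 1.4-fold higher number from compound 1 to compound 4 (0.15 log units; within the scatter) shows that this exchange of side chains leaves the number within the scatter. The exchange adds a carbonyl and replaces ethyl with methyl on the piperazine together, so this pair cannot separate the two changes. No measured evidence bears on this result.

Still open, on these data alone, is whether a longer chain carrying the piperazine, or a carboxylic acid or primary amine at the end of the chain, would move the number beyond the scatter.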